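The source may hold more compounds than are shown below. What is called first, only, known or untested is meant among the compounds shown, and "the series" means these compounds.

Compound 2, `CCOC(=O)CCCCCOc1cccc(CN(C(=O)c2ccc(-c3cccc(OC(C)C)c3)cc2)C(C)C)c1`, stands at the edge of what this series can show: in an ADME assay on HEK293 cells (Homo sapiens) for cytotoxicity, read by CellTiter-Glo and resazurin assay, with a stated time of 72 h (a lower number here means that less compound is needed, a higher number that more compound is needed for the effect), compound 2 gives > 26000 nM, which is a limit of the assay and not a number. Compound 1, `CC(C)Oc1cccc(-c2ccc(C(=O)N(Cc3cccc(OCCCCCC(=O)O)c3)C(C)C)cc2)c1`, gives > 26000 nM in this assay, again a limit. Compound 3, `CCOC(=O)CCCCCOc1cccc(CN(C(=O)c2ccc(-c3cccc(Oc4ccccc4)c3)cc2)C(C)C)c1`, gives > 19600 nM in this assay, also a limit. With every value sitting at a limit, the two steps recorded so far, a step that the two limits leave unreadable from compound 1 to compound 2 and a step that the two limits leave unreadable from compound 2 to compound 3, cannot be read; this follows because the limit of > 26000 nM in this assay, at which 2 of the 3 values shown sit, and because of the limit of > 19600 nM in this assay, at which 1 of the 3 values shown sits.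

Compound 4, `CCOC(=O)CCCCCOc1cccc(CN(C(=O)c2ccc(-c3ccc(Cl)c(Cl)c3)cc2)C(C)C)c1`, differs from compound 2 by 3,4-dichlorophenyl in place of 3-isopropoxyphenyl on an aromatic carbon. The step from compound 2 to compound 3 is the one that bears on it, since it also exchanges the group on that aromatic carbon, but its size is not readable. No step beyond the scatter is therefore expected here. The expected step from compound 2 to compound 4 in this assay is a number no higher from compound 2 to compound 4 (the limit leaves the size open). For compound 4 in this assay the estimate is 26000 nM, expected to lie between 13000 nM and 60000 nM, most likely reported again as a limit.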

Compound 4, half-maximal effective concentration: > 26000 nM
Compound 4: a limit, no number; the forecaster's own chance of this, stated with the estimate: 80%; the middle value lies on the limit itself.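

In this assay compound 4 gives > 26000 nM, a limit of the assay and not a number. For the compounds shown here, compound 2 also stands at a limit, and no step between compound 2 and compound 4 can be read. The compounds shown leave open at what concentration any of them reaches the half-maximal effect.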